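This account rests on a few compounds, and the source may have more. Where it says the series, first, only, none or still open, it means among the compounds named here.

Two compounds share one core and differ only at a saturated chain carbon bound to a carbonyl carbon and a sulfonamide nitrogen. Compound 1 `CC(C)(C)OC(=O)C[C@@H](NS(=O)(=O)Cc1ccccc1)C(=O)N1CCC[C@H]1C(=O)NCc1ccc(C(=N)N)cc1` carries a (tert-butoxycarbonyl)methyl group there; in an assay on isolated protein for inhibition of transmembrane protease serine 11D (Homo sapiens), read by fluorescence (on this read-out lower numbers stand for stronger inhibition and higher numbers for weaker inhibition), compound 1 gives 38 nM. Compound 2 `CC(C)[C@@H](NS(=O)(=O)Cc1ccccc1)C(=O)N1CCC[C@H]1C(=O)NCc1ccc(C(=N)N)cc1` carries an isopropyl group in its place, and in this assay compound 2 gives 76 nM. For the measured compounds named here, the step of a 2.0-fold higher number from compound 1 to compound 2 (0.30 log units; within the scatter) means the two numbers cannot be told apart, so compound 2 stands level with compound 1, and nothing measured so far sets either apart.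

Compound 3 `N=C(N)c1ccc(CNC(=O)[C@@H]2CCCN2C(=O)[C@@H](CC(=O)O)NS(=O)(=O)Cc2ccccc2)cc1` is the next variation at the same place: carboxymethyl in place of isopropyl on a saturated chain carbon bound to a carbonyl carbon and a sulfonamide nitrogen. Going by the values given here, the only step measured so far, from compound 1 to compound 2, bears on it only loosely, since it changed the same position and stayed within the scatter. Among the compounds with values here, no measured pair shows what a carboxymethyl group does here. With so little to go on, the expectation in this assay is a step of a 2.0-fold higher number from compound 2 to compound 3 (0.30 log units; within the scatter) that need not exceed the scatter, with wide uncertainty. Compound 3 is therefore estimated at 150 nM, with a range from 40 nM to 600 nM.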

Compound 3, inhibition constant: 1430 nM
Estimate against measurement, compound 3: 9.5-fold (0.98 log units) below, outside the stated range (above it).
By their numbers in this assay, from the lowest: compounds 1 and 2 (each within the scatter of the next); then compound 3.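

The first pair suggested that this position tolerates quite different groups, since the (tert-butoxycarbonyl)methyl and isopropyl groups could not be told apart in this assay. Compound 3 shows that this tolerance has a limit: carboxymethyl in place of isopropyl gives a large step beyond the scatter (a 19-fold higher number from compound 2 to compound 3 (1.27 log units; beyond the scatter)), and hydrogen in place of tert-butyl on an oxygen next to a carbonyl group gives a similarly large one (a 38-fold higher number from compound 1 to compound 3 (1.58 log units; beyond the scatter)), so compound 3 is the weakest of the three inhibitors and a change confined to the tert-butyl group is enough to produce the loss. The two routes to compound 3 therefore agree, whichever neighbour serves as the reference, yet the data offered here contain no independent measurement that could explain why this group costs so much.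

For the compounds shown here, with only three groups at this place, it remains open whether the loss belongs to the carboxymethyl group specifically or would also appear with an aminomethyl group or a primary amide. A longer chain ending in a carboxylic acid, or a methyl ester in place of the tert-butyl ester, would also help show how far along the chain the sensitivity extends.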